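Swapping an aryl group on a shared oxazole-type core

The compounds below may be only part of what the source reports. "The series", "measured", "known", "first", "only" and "open" are said of these compounds alone.

Measured compounds:
- Compound 1, `Cc1cc(C)c(-c2nc(CN3CCC(C(=O)NCCCN4C[C@H](C)C[C@H](C)C4)CC3)c(C)o2)c(C)c1`: "not determined" (no result reported)
- Compound 2, `Cc1ccccc1-c1nc(CN2CCC(C(=O)NCCCN3CC(C)(C)CC(C)(C)C3)CC2)c(C)o1`: > 1390 10^-6 cm/s
- Compound 3, `Cc1cccc(Cl)c1-c1nc(CN2CCC(C(=O)NCCCN3CCC(C(C)C)CC3)CC2)c(C)o1`: "not determined" (no result reported)

Three compounds share a core and differ in the aromatic group attached to it and in the ring at the far end of the chain. In a physicochemical assay for permeability, using PAMPA (a lower number here means that the compound crosses the layer more slowly, a higher number that the compound crosses the layer faster), compound 1 has no result: "not determined" (no result reported). Compound 3 likewise has no result in this assay: "not determined" (no result reported). Compound 2 in this assay reaches > 1390 10^-6 cm/s, which is a limit of the assay and not a number. So (the limit of > 1390 10^-6 cm/s in this assay, at which 1 of the 3 values shown sits), and compound 1 stands without a number of its own.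

The new compound 4, `Cc1cccc(F)c1-c1nc(CN2CCC(C(=O)NCCCN3C[C@H](C)C[C@H](C)C3)CC2)c(C)o1`, differs from compound 1 in one place: 2-fluoro-6-methylphenyl in place of 2,4,6-trimethylphenyl on an aromatic carbon.

Among the compounds with values here, no step between two measured compounds is known here, so the size of the step from compound 1 to compound 4 in this assay cannot be read from the data. Within the data shown here, the only number in the set is the limit reached by compound 2, a close relative. On that basis compound 4 is expected to cross the layer quickly, with a good chance that only a limit is reported. The estimate for compound 4 is 1200 10^-6 cm/s, expected between 350 10^-6 cm/s and 2000 10^-6 cm/s.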

Compound 4, apparent permeability: 234 10^-6 cm/s
For compound 4 the middle estimate is 5.1-fold (0.71 log units) above the measured one; the whole stated range lies above it.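

In this assay, within the data shown here, compound 4 gives 234 10^-6 cm/s, but compound 1 has no number to set against it, so no step between compound 1 and compound 4 can be read. The compounds shown leave open how replacing 2,4,6-trimethylphenyl with 2-fluoro-6-methylphenyl, taken alone, shifts the value in this assay.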